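Changing the Aryl Ring on a Triazole Amide

The source may hold more compounds than are shown below. What is called first, only, known or untested is meant among the compounds shown, and "the series" means these compounds.

Compound 1, `COc1cc2c(Oc3ccc(NC(=O)c4cn(-c5ccccc5)nn4)cc3F)ccnc2cc1OCCCN1CCCCC1`, gives 130 nM in a functional assay on A549 cells (Homo sapiens) for cytotoxicity, read by MTT assay, with a stated time of 72 h; a lower number here means a stronger inhibitor, a higher number a weaker inhibitor.
For compound 2, `COc1cc2c(Oc3ccc(NC(=O)c4cn(-c5c(C)cccc5C)nn4)cc3F)ccnc2cc1OCCCN1CCCCC1`, the entry in this assay reads "not determined" (no result reported), so no reported result exists for it.

Compound 2 therefore stands nowhere on the numbers: it carries a 2,6-dimethylphenyl group on the triazole nitrogen, but no single value was recorded for it, so it cannot be placed against compound 1 in this assay. Compound 3, `COc1cc2c(Oc3ccc(NC(=O)c4cn(-c5ccc(F)c(F)c5)nn4)cc3F)ccnc2cc1OCCCN1CCCCC1`, is the next compound and has not yet been tested. Among the measured compounds shown here, its only difference from compound 2 is 3,4-difluorophenyl in place of 2,6-dimethylphenyl on an aromatic nitrogen. With no measured value for compound 2, the size of the step from compound 2 to compound 3 in this assay cannot be set against any measured change, and no direction is known. For the measured compounds named here, the only anchor is compound 1, which gives 130 nM with the plain phenyl ring in this assay. Compound 3 is therefore expected to fall near that figure, around 130 nM, with a likely range from 40 nM to 500 nM.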

Compound 3, half-maximal inhibitory concentration: 220 nM
Beside the measured number, compound 3's estimate is 1.7-fold (0.23 log units) below it; measured number inside the range.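

Among the compounds shown here, putting 3,4-difluorophenyl in place of phenyl on an aromatic nitrogen gives a 1.7-fold higher number from compound 1 to compound 3 (0.23 log units; within the scatter) in this assay and is the first step at this position that can be read. The aryl ring here can therefore carry two fluorines with no shift that stands clear of the usual scatter between repeated measurements. The step between compound 2 and compound 3 cannot be read, as compound 2 has no reported result. No measurement shown gives a reason for this outcome. Still open, on these data alone, is how this position would respond in this assay to a phenyl ring bearing an amine, a carboxylic acid or a longer chain, or to a plain alkyl group such as cyclohexyl in place of the aryl ring.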